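The compounds below may be only part of what the source reports. "The series", "measured", "known", "first", "only" and "open" are said of these compounds alone.

Measured so far:
Compound 1, `O=C1CC(c2nc(-c3cccc(Cl)c3)no2)CN1c1ccc(Cl)cc1`: 140 nM
Compound 2, `Cc1ccc(N2CC(c3nc(-c4cccc(Cl)c4)no3)CC2=O)cc1C`: 310 nM

Among the measured compounds shown here, in an in vitro functional assay on HEK293-A cells for positive allosteric modulation of metabotropic glutamate receptor 5 (Homo sapiens), read by FLIPR and calcium flux (a lower number here means that less compound is needed, a higher number that more compound is needed for the effect), compound 1 holds the lower of the two numbers; the only measured step, a 2.2-fold higher number from compound 1 to compound 2 (0.35 log units; beyond the scatter), swaps the group on the amide-type nitrogen and so says nothing about the other end of the core. Compound 3, `O=C1CC(c2nc(-c3cccc(F)c3)no2)CN1c1ccc(Cl)cc1`, differs from compound 1 there: fluoro in place of chloro on an aromatic carbon. For the measured compounds named here, with no measured step at that place, the expectation rests on the change alone, and a modest rise in the number is expected, a 2.5-fold higher number from compound 1 to compound 3 (0.40 log units; beyond the scatter). Compound 3 is therefore expected to give 350 nM, within a range of 120 nM to 1200 nM.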

Compound 3, half-maximal effective concentration: 630 nM
For compound 3 the middle estimate is 1.8-fold (0.26 log units) below the measured one; the measured number falls inside the stated range.
By their numbers in this assay, from the lowest: compound 1; then compound 2; then compound 3.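

In this assay, this position on the aromatic ring responds to an exchange of one halogen for another: 3-fluorophenyl in place of 3-chlorophenyl gives a 4.5-fold higher number from compound 1 to compound 3 (0.65 log units; beyond the scatter), so the chloro of compound 1 gives the lower number of these two. Nothing available explains this difference.

From the compounds shown here alone, whether chloro is especially favourable here or fluoro is unfavourable remains open. Compounds carrying bromo, methyl or methoxy at this place, or simply hydrogen, would help separate these possibilities.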